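The source may report more compounds than this note shows. Statements on the series, on what has been measured and on what is new or still open speak of the compounds shown alone.

Two compounds have been measured in a functional assay on OVCAR-8 cells (Homo sapiens) (on this read-out higher numbers stand for weaker inhibition of growth and lower numbers for stronger inhibition of growth), so far:
- compound 1 `O=S(=O)(/C=C/c1ccc(F)cc1Cl)Cc1ccc(Nc2ncnc3ccccc23)cc1` with 100000 nM as its value
- compound 2 `O=S(=O)(/C=C/c1ccc(C(F)(F)F)cc1F)Cc1ccc(Nc2ncnc3cc(Cl)ccc23)cc1` with > 100000 nM as a limit of the assay

In this assay compound 2 reaches only the limit > 100000 nM and gives no number.

Compound 3 `O=S(=O)(/C=C/c1ccc(F)cc1Cl)Cc1ccc(Nc2ncnc3cc(Cl)ccc23)cc1` carries 2-chloro-4-fluorophenyl in place of 2-fluoro-4-(trifluoromethyl)phenyl on a double-bonded chain carbon bound to a double-bonded chain carbon. Among the measured compounds shown here, no measured step between compounds that differ in one place is available as a guide. Compound 1 reads 100000 nM in this assay and so only a small step toward stronger inhibition of growth is expected, perhaps none beyond the scatter. The estimate means an at least 1.4-fold lower number from compound 2 to compound 3 (0.15 log units; that floor lies within the scatter) as the expected step. For compound 3 the estimated value is 70000 nM with an expected range from 20000 nM to 100000 nM as its upper end.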

Compound 3, concentration for 50% growth inhibition: > 100000 nM
Compound 3 gave a limit, no number; the forecaster's own chance of this, stated with the estimate: 45%; middle value at least 1.4-fold (0.15 log units) away from the limit.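

In this assay, 2-chloro-4-fluorophenyl in place of 2-fluoro-4-(trifluoromethyl)phenyl on a double-bonded chain carbon bound to a double-bonded chain carbon brings no number into range, and compound 3 gives only the limit > 100000 nM. Chloro in place of hydrogen on an aromatic carbon gives a number no lower from compound 1 to compound 3 (the limit leaves the size open), so this change shows no gain in inhibition of growth. The step linking compound 2 and compound 3 cannot be read, and the values shown leave little to compare: the limit of > 100000 nM in this assay, at which 2 of the 3 values shown sit.

On these data alone, whether 2-chloro-4-fluorophenyl and 2-fluoro-4-(trifluoromethyl)phenyl differ at all on this read-out stays open. Also open, as far as these compounds go, is whether an amine or a carboxylic acid at this place would give a value clear of the limit.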